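Aryl group changes on the shared core

The source may report more compounds than this note shows. Statements on the series, on what has been measured and on what is new or still open speak of the compounds shown alone.

Compound 2 `CCCCCCCCCCCCCCCCCCNC(=O)[C@@H]1CSC(c2ccc(OC)cc2)N1` gives 8700 nM in a functional assay on DU-145 cells (Homo sapiens) for antiproliferative activity, read by sulforhodamine B assay (a higher number here means a weaker inhibitor, a lower number a stronger inhibitor), and compound 1 `CCCCCCCCCCCCCCCCCCNC(=O)[C@@H]1CSC(c2cccc(O)c2)N1` gives 5700 nM in this assay. Compound 2 stands as the higher of these two numbers, but the step of a 1.5-fold higher number from compound 1 to compound 2 (0.18 log units; within the scatter) leaves the two within the scatter, so no order between them is claimed.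

Compound 3 `CCCCCCCCCCCCCCCCCCNC(=O)[C@@H]1CSC(c2cc(OC)c(OC)c(OC)c2)N1` differs from compound 2 by 3,4,5-trimethoxyphenyl in place of 4-methoxyphenyl on a saturated ring carbon. For the measured compounds named here, the only measured step on this aryl group, a 1.5-fold higher number from compound 1 to compound 2 (0.18 log units; within the scatter), was within the scatter; it bears on compound 3 only loosely, since it exchanged one single substituent for another, while compound 3 carries two further methoxy groups. Going by the values given here, no measured step covers such an addition. On these two numbers alone, the expectation for compound 3 is no step beyond the scatter in this assay, namely a 1.1-fold lower number from compound 2 to compound 3 (0.04 log units; within the scatter). Compound 3 is estimated at 8000 nM, with a range from 3000 nM to 25000 nM.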

Compound 3, half-maximal inhibitory concentration: 3900 nM
Beside the measured number, compound 3's estimate is 2.1-fold (0.31 log units) above it, and the stated range covers the measured number.
By their numbers in this assay, from the lowest: compounds 3, 1 and 2 (each within the scatter of the next, the first and the last beyond it).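

In this assay this aryl position now gives its first step beyond the scatter: with 3,4,5-trimethoxyphenyl in place of 4-methoxyphenyl on the saturated ring carbon, the change is a 2.2-fold lower number from compound 2 to compound 3 (0.35 log units; beyond the scatter) and remains modest in size. Against the 3-hydroxyphenyl group, the same 3,4,5-trimethoxyphenyl group gives a 1.5-fold lower number from compound 1 to compound 3 (0.16 log units; within the scatter) and so separates compound 3 from compound 2 only, not from compound 1. No measured evidence bears on the origin of this step.

Whether one of the two further methoxy groups alone accounts for the step remains open, and an aryl group carrying two methoxy groups would test this. Also open, as far as these compounds go, is how an amine or a carboxylic acid on the aryl ring would behave in this assay on the shared core.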